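The source may report more compounds than this note shows. Statements on the series, on what has been measured and on what is new or still open speak of the compounds shown alone.

Measured so far in an assay on isolated protein for inhibition of aldehyde dehydrogenase 1A1 (Homo sapiens), read by spectrophotometry, tested at 10 uM; a lower number here means less inhibition, a higher number more inhibition at the concentration tested (going by the name of the read-out):
- compound 1 `CCC(=O)N1CCN(Cc2nc3ccccc3n2Cc2cccc(C)c2)CC1` gives 85.1%
- compound 2 `COc1ccc(C(=O)N2CCN(Cc3nc4ccccc4n3Cc3cccc(C)c3)CC2)cc1` gives 55.5%
- compound 3 `O=C(C1CC1)N1CCN(Cc2nc3ccccc3n2Cc2ccccc2C(F)(F)F)CC1` gives 56.3%

Compound 3 stands second highest of the three numbers. Its nearest neighbour is compound 2, whose number lies within the scatter of that of compound 3, so no order between these two can be read. The furthest is compound 1, which lies beyond the scatter above compound 3.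

Among the measured compounds shown here, the one step measured so far, a number 29.6 percentage points lower from compound 1 to compound 2 (beyond the scatter), concerns the group on the carbonyl carbon. The step from compound 3 to compound 4 `O=C(C1CC1)N1CCN(Cc2nc3ccccc3n2CC2CC2)CC1` lies elsewhere: cyclopropyl in place of 2-(trifluoromethyl)phenyl on a saturated chain carbon bound to an aromatic nitrogen. For the measured compounds named here, no measured pair shows a change at this position, since compounds 1 and 2 both carry the same group there and compound 3 differs from them at two places at once. The step on the carbonyl carbon therefore gives no direct guide to the size or direction at hand; it only shows that a modest change in one part of the series can move this assay beyond the scatter.

Given the loss of the whole aromatic ring with its trifluoromethyl at this position, the working expectation for compound 4 is a drop beyond the scatter, estimated as a number 21.3 percentage points lower from compound 3 to compound 4 (beyond the scatter). For compound 4 the estimate in this assay is 35%, with a range from 10% to 62%.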

Compound 4, a percentage reported as inhibition, at one concentration (the size of the read-out at that concentration, not a potency): 21.2%
Beside the measured number, compound 4's estimate is 13.8 percentage points above it, and the stated range covers the measured number.
By their numbers in this assay, from the lowest: compound 4; then compounds 2 and 3 (each within the scatter of the next); then compound 1.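

In this assay the position on a saturated chain carbon bound to an aromatic nitrogen now has its first measured single change: cyclopropyl in place of 2-(trifluoromethyl)phenyl gives a number 35.1 percentage points lower from compound 3 to compound 4 (beyond the scatter) with the cyclopropyl on the carbonyl carbon held constant. This position can therefore move the read-out beyond the scatter, and the 10 heavy atoms of the leaving group are not interchangeable here with the 3 of cyclopropyl. No available evidence bears on why the number falls.

The compounds shown do not separate the aromatic ring from the trifluoromethyl, a question that an unsubstituted phenyl, a cyclohexyl or a longer chain such as n-butyl at this place would address. As far as these compounds go, whether the step holds with ethyl on the carbonyl carbon also remains open.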